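The source may report more compounds than this note shows. Statements on the series, on what has been measured and on what is new or still open speak of the compounds shown alone.

Measured so far in an ADME assay on L1210/0 cells (Mus musculus) for cytotoxicity, with a stated time of 48 h; a higher number here means a weaker inhibitor, a lower number a stronger inhibitor:
- compound 1 `O=c1[nH]c(=O)n([C@H]2C[C@H](O)[C@@H](CO)O2)cc1/C=N/O` gives 15500 nM
- compound 2 `O=c1[nH]c(=O)n([C@H]2C[C@H](O)[C@@H](CO)O2)cc1[N+](=O)[O-]` gives 130 nM
- compound 3 `O=c1[nH]c(=O)n([C@@H]2CCC[C@H]2CO)cc1I` gives > 200000 nM (a limit, not a number)

Compound 3 has no number, only a limit, which is the limit of > 200000 nM in this assay, at which 1 of the 3 values shown sits.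

Compound 4 `O=c1ccn([C@@H]2CCC[C@H]2CO)c(=O)[nH]1` carries hydrogen in place of iodo on an aromatic carbon, (hydrogen in place of iodo on an aromatic carbon). Among the measured compounds shown here, the only measured step on an aromatic carbon is a 120-fold lower number from compound 1 to compound 2 (2.08 log units; beyond the scatter). It swaps other groups on a different core, so it gives neither size nor direction for this change. No shift beyond the scatter is therefore expected in this assay. The expected step is a number no higher from compound 3 to compound 4 (the limit leaves the size open). Compound 4 is estimated at 200000 nM, within a range of 60000 nM to 500000 nM, and may well be reported only as a limit.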

Compound 4, half-maximal inhibitory concentration: > 200000 nM
Compound 4: a limit, no number; the forecaster's own chance of this, stated with the estimate: 80%; the middle value sits exactly at the limit.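

Compound 3 and compound 4 both stand only as limits, so no step can be read between them: the limit of > 200000 nM in this assay, at which 2 of the 4 values shown sit.

In this assay the compounds shown leave open whether hydrogen in place of iodo on this aromatic carbon changes the read-out at all.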